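Swapping Methoxy for Bromo in a Cytotoxicity Series

The source may hold more compounds than are shown below. What is called first, only, known or untested is meant among the compounds shown, and "the series" means these compounds.

Three compounds sharing one core were tested in a functional assay on HL-60 cells (Homo sapiens) for cytotoxicity, read by MTT assay, with a stated time of 4 days; on this read-out lower numbers stand for stronger inhibition and higher numbers for weaker inhibition. Compound 1 `C=C1C[C@]23C[C@@]1(O)CC[C@@H]2c1cccc(C)c1[C@@H]3Cn1cc(-c2ccc(OC)cc2)nn1` reaches only the limit of the measurement there, giving > 20000 nM, so no number is known for it. Compound 2 `C=C1C(=O)[C@]23C[C@@]1(O)CC[C@H]2c1ccc(O)c(C)c1[C@@H]3Cn1cc(-c2ccc(F)cc2)nn1` differs from compound 1 at several places in the core and in the outer ring, and in this assay compound 2 gives 660 nM. Compound 3 `C=C1C[C@]23C[C@@]1(O)CC[C@H]2c1ccc(O)c(C)c1[C@@H]3Cn1cc(-c2ccc(Br)cc2)nn1` also sits at the limit, giving > 20000 nM in this assay. Going by the values given here, because of the limit of > 20000 nM in this assay, at which 2 of the 3 values shown sit, compound 1 stands among the weaker members here, with compound 2 the only one that gives a number.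

Compound 4 `C=C1C[C@]23C[C@@]1(O)CC[C@@H]2c1cccc(C)c1[C@@H]3Cn1cc(-c2ccc(Br)cc2)nn1` is the next member. It is made from compound 1 by one change: bromo in place of methoxy on an aromatic carbon. Among the compounds with values here, no pair of measured compounds differs only in this way, so the size of this step is not known from the data. The expected step of a number no higher from compound 1 to compound 4 (the limit leaves the size open) is none beyond the scatter, because compound 3 carries the same bromo and gives > 20000 nM. Compound 4 is therefore expected to give about 20000 nM, within a range from 8000 nM to 50000 nM.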

Compound 4, half-maximal inhibitory concentration: > 20000 nM
Compound 4: no number, only a limit; the forecaster's own chance of this, stated with the estimate: 75%; the middle value lies on the limit itself.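

Compound 1 and compound 4 each give only a limit of the measurement, not a number, so no step can be read for bromo in place of methoxy. The compounds shown leave open whether going from 4-methoxyphenyl to 4-bromophenyl changes the cytotoxicity at all, and by how much.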